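The compounds below may be only part of what the source reports. "The series", "measured", "known", "first", "only" and "open" are said of these compounds alone.

In an in vivo ADME assay on the whole organism (strain Sprague-Dawley) for pharmacokinetics, with Rattus norvegicus as the target, at a dose of 2 mg/kg by the intravenous route (a higher number here means that the compound lasts longer, a lower number that the compound disappears faster), compound 1 (`O=C(CC(c1ccccc1)c1ccccc1)N1CCN(C(c2ccccc2)c2cccc(Cl)c2)CC1`) gives a half-life of 8 h, and compound 2 (`O=C(NC(c1ccccc1)c1ccccc1)N1CCN(C(c2ccccc2)c2ccccc2)CC1`) gives 11 h. Going by the values given here, these two numbers lie within the scatter of each other, so the data do not set compound 1 apart from the only other measured compound. Compound 3 (`O=C(CC(c1ccccc1)c1ccccc1)N1CCN(C(c2ccccc2)c2cccc(C(F)(F)F)c2)CC1`) keeps the rest of compound 1 and carries trifluoromethyl in place of chloro on an aromatic carbon, meta to a large group: trifluoromethyl in place of chloro on an aromatic carbon. Among the compounds with values here, no measured pair shows this replacement, so the expectation rests on compound 1 and its 8 h. In this assay, no change beyond the scatter is expected, and the estimated step is no change at the digits printed from compound 1 to compound 3 (within the scatter). Compound 3 is expected to give 8 h, with an estimated range from 4 h to 16 h.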

Compound 3, half-life: 5 h
For compound 3 the middle estimate is 1.6-fold (0.20 log units) above the measured one; the measured number falls inside the stated range.
By their numbers in this assay, from the lowest: compounds 3, 1 and 2 (each within the scatter of the next, the first and the last beyond it).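

In this assay, going by these compounds alone, the step of a 1.6-fold lower number from compound 1 to compound 3 (0.20 log units; within the scatter) is the first comparison that changes a single place, and it isolates the swap of chloro for trifluoromethyl on an aromatic carbon, meta to a large group. It shows that 3-chlorophenyl can give way to 3-(trifluoromethyl)phenyl on the core of compound 1 without the half-life leaving the usual scatter, although the entering group is larger by count of heavy atoms. Nothing in the data speaks to the cause of this result.

The compounds shown leave open whether a group of another kind at this position, such as an amine, a carboxylic acid or a methoxy group, would move the half-life beyond the scatter. They also leave open whether trifluoromethyl would read the same elsewhere on this ring.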